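Swapping a chlorophenyl for a methylphenyl in a weak series

The source may hold more compounds than are shown below. What is called first, only, known or untested is meant among the compounds shown, and "the series" means these compounds.

Compound 1 `COc1ccc(-c2ccnc(C(=O)Nc3ccc(Oc4ccnc5[nH]ccc45)cc3)c2)cc1`: 8210 nM in a functional assay on MCF7 cells (Homo sapiens) for cytotoxicity, read by MTT assay, with a stated time of 72 h; a lower number here means a stronger inhibitor, a higher number a weaker inhibitor
Compound 2 `O=C(Nc1ccc(Oc2ccnc3[nH]ccc23)cc1)c1cc(-c2ccc(Cl)cc2)ccn1`: > 10000 nM

For compound 2 the value is the limit of > 10000 nM in this assay, at which 1 of the 2 values shown sits, a limit of the assay and not a number. Among the measured compounds shown here, the only measured step, an at least 1.2-fold higher number from compound 1 to compound 2 (0.08 log units; that floor lies within the scatter), came with chloro in place of methoxy on an aromatic carbon and is bounded by that limit. Compound 3 `Cc1cccc(-c2ccnc(C(=O)Nc3ccc(Oc4ccnc5[nH]ccc45)cc3)c2)c1` carries 3-methylphenyl in place of 4-chlorophenyl on an aromatic carbon. Nothing measured separates a methyl from a chloro at this place, so no step beyond the scatter is expected. Compound 3 is therefore expected to give 10000 nM, with a range from 4000 nM to 25000 nM, an expected step of a number no higher from compound 2 to compound 3 (the limit leaves the size open).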

Compound 3, half-maximal inhibitory concentration: 7470 nM
The estimate for compound 3 lay 1.3-fold (0.13 log units) above the measured number; the measured number falls inside the stated range.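

Compound 2 stands at a limit and not at a number: the limit of > 10000 nM in this assay, at which 1 of the 3 values shown sits. As far as these compounds go, replacing its 4-chlorophenyl with 3-methylphenyl gives an at least 1.3-fold lower number from compound 2 to compound 3 (0.12 log units; that floor lies within the scatter), so the true size of this change stays unknown. Replacing 4-methoxyphenyl with 3-methylphenyl gives a 1.1-fold lower number from compound 1 to compound 3 (0.04 log units; within the scatter), so these two differently substituted phenyl groups, opposite the ring nitrogen, cannot be told apart in this assay.

Still open, from the compounds shown here alone, is whether a phenyl group carrying an amine or a carboxylic acid would move the number beyond the scatter. Also open, going by these compounds, is whether 4-methylphenyl would read like 3-methylphenyl.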